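A few compounds are considered here, and "the series" means these few. Any claim that something is new, unique, unknown or untested is made for them only; others in the source may bear on it.

Of the compounds shown here, three built on one shared core have been measured in a functional assay on MDA-MB-231 cells (Homo sapiens) for antiproliferative activity, read by MTT assay, with a stated time of 72 h; on this read-out higher numbers stand for weaker inhibition and lower numbers for stronger inhibition. Compound 1 `COc1ccc(-c2noc3c2/C(=N/OC(=O)c2cccc(NC(=O)c4cccc(F)c4)c2)CCC3)cc1OC` reaches only the limit of this assay, > 25000 nM. Compound 2 `COc1cccc(C(=O)Nc2cccc(C(=O)O/N=C3\CCCc4onc(-c5ccc(OC)c(OC)c5)c43)c2)c1`, which carries methoxy in place of fluoro on an aromatic carbon, likewise gives only a limit, > 25000 nM. The step that the two limits leave unreadable from compound 1 to compound 2 is for that reason unreadable in size. Compound 3 `Nc1cccc(C(=O)Nc2cccc(C(=O)O/N=C3\CCCc4onc(-c5ccc(F)cc5)c43)c2)c1` also stands at a limit, > 25000 nM. Going by the values given here, every value so far sits at the limit of > 25000 nM in this assay, at which 3 of the 3 values shown sit, so none of the measured steps has a readable size and no ordering among compounds 1, 2 and 3 can be stated.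

Compound 4 `COc1ccc(-c2noc3c2/C(=N/OC(=O)c2cccc(NC(=O)c4cccc(N)c4)c2)CCC3)cc1OC` has not yet been measured. It differs from compound 3 by 3,4-dimethoxyphenyl in place of 4-fluorophenyl on an aromatic carbon. Among the compounds with values here, no measured pair shows this exchange directly; the only measured step, from compound 1 to compound 2, concerns a different position and is itself unreadable. Within the data shown here, because all three known values sit at the limit of > 25000 nM in this assay, at which 3 of the 3 values shown sit, there is no evidence of any compound falling below the limit, and the expected step that the limit leaves unreadable from compound 3 to compound 4 is therefore none beyond the scatter, with the most likely outcome again a limit rather than a number. Compound 4 is estimated at 30000 nM in this assay, within a range from 10000 nM to 100000 nM.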

Compound 4, half-maximal inhibitory concentration: > 25000 nM
Compound 4 was reported as a limit; the forecaster's own chance of this, stated with the estimate: 85%; the middle value is on the limit's open side.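

In this assay compound 4 also stands at a limit, so none of its steps to compound 1, compound 2 and compound 3 can be read: the limit of > 25000 nM in this assay, at which 4 of the 4 values shown sit. The compounds shown leave open how large any of these exchanges is, and whether any compound on the shared core gives a number rather than a limit.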